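Shifting the Pyridyl Group on the Sulfonyl Sulfur

A few compounds are considered here, and "the series" means these few. Any claim that something is new, unique, unknown or untested is made for them only; others in the source may bear on it.

Compounds 1 to 4 share one core and differ only in the aromatic group attached to a sulfonyl sulfur. Compound 1 `CNCc1cn(S(=O)(=O)c2ncccc2C)c(-c2cccnc2F)c1F` was tested in a functional assay on the whole organism (strain Jcl:Sprague-Dawley) for inhibition, with Rattus norvegicus as the target, with stated times of 3 min and 3 h, at a dose of 1 mg/kg by the intravenous route (on this read-out higher numbers stand for more inhibition at the one dose given (going by the name of the read-out) and lower numbers for less inhibition), and gave 54%. Compound 2 `CNCc1cn(S(=O)(=O)c2cccc(C)n2)c(-c2cccnc2F)c1F`, which carries a different pyridyl group on the same sulfur, gave 91% in this assay. The step of a number 37 percentage points higher from compound 1 to compound 2 (beyond the scatter) shows that moving the methyl group on the pyridyl ring alone can change the read-out considerably. Compound 3 `CNCc1cn(S(=O)(=O)c2cccc(F)n2)c(-c2cccnc2F)c1F` has a fluoropyridyl group on the sulfonyl sulfur, but in this assay compound 3 gave "not determined" (no result reported), so compound 3 cannot be placed on the scale that compounds 1 and 2 define.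

Compound 4 `CNCc1cn(S(=O)(=O)c2cccnc2C)c(-c2cccnc2F)c1F` is the next variant. Compared with compound 3 it shows the following change: 2-methylpyridin-3-yl in place of 6-fluoropyridin-2-yl on a sulfonyl sulfur. For the measured compounds named here, the only measured step, from compound 1 to compound 2, concerns a change of the same kind, a pyridyl group on the sulfonyl sulfur, and it was large. Going by the values given here, no measured pair links directly to compound 4, so the direction for it remains open. Compound 4 is expected to land in the range spanned by compounds 1 and 2, with an estimated 65%, somewhere between 35% and 92%.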

Compound 4, a percentage reported as inhibition, in the whole organism at one dose (the size of the read-out at that dose, not a potency): 92%
For compound 4 the middle estimate is 27 percentage points below the measured one, and the stated range covers the measured number.
By their numbers in this assay, from the lowest: compound 1; then compounds 2 and 4 (each within the scatter of the next).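

In this assay, for the compounds shown here, exchanging the 6-methylpyridin-2-yl group on the sulfonyl sulfur for 2-methylpyridin-3-yl gives a number 1 percentage points higher from compound 2 to compound 4 (within the scatter), so two different methylpyridyl groups at this place can give matching read-outs, something the single large step seen earlier could not show. Exchanging 3-methylpyridin-2-yl for the same 2-methylpyridin-3-yl group gives a number 38 percentage points higher from compound 1 to compound 4 (beyond the scatter), so a second, separate change also clears the scatter and compound 1 now stands apart from both other measured compounds, even though all three carry a methylpyridyl group on this sulfur. Nothing available here explains why the 3-methylpyridin-2-yl group differs from the other two, and the data show only that it does.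

From the compounds shown here alone, with no number for compound 3, the 6-fluoropyridin-2-yl group cannot be compared with any methylpyridyl group, so the effect of fluorine in place of methyl on this ring stays unknown. Going by these compounds, it also remains open how a plain phenyl group, or a pyridyl ring carrying a methoxy group or an amine, would behave on this sulfur.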